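A few compounds are considered here, and "the series" means these few. Any claim that something is new, unique, unknown or untested is made for them only; others in the source may bear on it.

Measured compounds in a functional assay on HT-29 cells (Homo sapiens) for inhibition, read by MTT assay, with a stated time of 48 h; a lower number here means a stronger inhibitor, a higher number a weaker inhibitor:

compound 1 `Cc1ccc(NC(=S)NC(=O)c2ccc(OCc3ccc(C(F)(F)F)cc3)cc2)cc1-c1nc2ccccc2[nH]1` gives 17600 nM
compound 2 `Cc1ccc(NC(=S)NC(=O)c2ccc(OCc3cccc(C(F)(F)F)c3)cc2)cc1-c1nc2ccccc2[nH]1` gives 8200 nM
compound 3 `Cc1ccc(NC(=S)NC(=O)c2ccc(OCc3ccccc3F)cc2)cc1-c1nc2ccccc2[nH]1` gives 1870 nM

Compound 3 holds the lowest number of the three in this assay; its nearest neighbour is compound 2, and compound 1 sits furthest away. The three measured steps all change the substituted benzyl group on the oxygen of the shared core: a 2.1-fold lower number from compound 1 to compound 2 (0.33 log units; beyond the scatter), a 9.4-fold lower number from compound 1 to compound 3 (0.97 log units; beyond the scatter) and a 4.4-fold lower number from compound 2 to compound 3 (0.64 log units; beyond the scatter). Every step that moves toward compound 3 lowers the number, and all three lie beyond the scatter.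

Compound 4 `Cc1ccc(NC(=S)NC(=O)c2ccc(OCc3ccccc3Cl)cc2)cc1-c1nc2ccccc2[nH]1` differs from compound 3 by chloro in place of fluoro on an aromatic carbon. Going by the values given here, no measured step swaps one halogen for another at this position; the steps from compound 1 and compound 2 to compound 3 show only that this ring tolerates changes of substituent with modest shifts. Among the compounds with values here, with no closer precedent, the expectation for compound 4 is a step no larger than the scatter, a 1.2-fold lower number from compound 3 to compound 4 (0.10 log units; within the scatter). Compound 4 is therefore estimated at 1500 nM, with a range from 500 nM to 5000 nM.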

Compound 4, half-maximal inhibitory concentration: 23700 nM
Compound 4: the middle estimate sits 16-fold (1.20 log units) below what was measured; the measured number lies above the stated range.
By their numbers in this assay, from the lowest: compound 3; then compound 2; then compounds 1 and 4 (each within the scatter of the next).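

In this assay, going by these compounds alone, chloro in place of fluoro on an aromatic carbon, ortho to a large group, is far from a neutral halogen exchange: it gives a 13-fold higher number from compound 3 to compound 4 (1.10 log units; beyond the scatter), the largest step so far. The low number of compound 3 therefore belongs to the 2-fluorobenzyl group in particular and not to any halogen at this place, since 2-chlorobenzyl gives a 2.9-fold higher number from compound 2 to compound 4 (0.46 log units; beyond the scatter) and, within the scatter, a 1.3-fold higher number from compound 1 to compound 4 (0.13 log units; within the scatter). No measured evidence accounts for the size of this step.

Still open, from the compounds shown here alone, is whether bromo, methoxy or an amine at this place would fall with compound 3 or with compound 4, and where the benzyl group without a substituent would stand. The shown compounds also leave open whether chloro in place of fluoro gives a step of similar size elsewhere on this ring.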